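A few compounds are considered here, and "the series" means these few. Any claim that something is new, unique, unknown or untested is made for them only; others in the source may bear on it.

Measured so far:
compound 1 `Cc1ccc(-c2cccc(CNc3ccc(OCC(=O)O)c(F)c3)c2)c(Cl)c1`, 22.5 nM
compound 2 `CCCOc1ccc(-c2cccc(CNc3ccc(OCC(=O)O)c(F)c3)c2)c(C)c1`, 41.3 nM

Both numbers come from a functional assay on CHO cells for agonist activity at Free fatty acid receptor 1 (Homo sapiens), read by FLIPR and calcium flux; on this read-out higher numbers stand for an effect only at larger amounts of compound and lower numbers for an effect already at smaller amounts. Compound 2 stands at the highest of the two numbers; its nearest neighbour is compound 1, and the gap between the two lies within the scatter, so no order between them can be read. Among the measured compounds shown here, no two measured compounds differ in one place only, so the series gives no measured step to lean on.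

Compound 3 `Cc1cc(O)ccc1-c1cccc(CNc2ccc(OCC(=O)O)c(F)c2)c1` is the next entry. Against compound 2 the change is hydrogen in place of propyl on an oxygen on an aromatic ring; the same difference, cut one bond further out, reads propoxy to hydroxy. For the measured compounds named here, the propyl is the only chain on that end of the shared core, and nothing among the measured compounds shows what its removal does. The working expectation is a move to a higher number, beyond the scatter but not by a large margin. The expected step from compound 2 to compound 3 in this assay is a 3.6-fold higher number from compound 2 to compound 3 (0.56 log units; beyond the scatter). Compound 3 is therefore estimated at 150 nM in this assay. The expected range for compound 3 runs from 50 nM to 500 nM.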

Compound 3, half-maximal effective concentration in the Free fatty acid receptor 1 assay: 69.6 nM
Beside the measured number, compound 3's estimate is 2.2-fold (0.33 log units) above it; the measured number falls inside the stated range.
By their numbers in the Free fatty acid receptor 1 assay, from the lowest: compounds 1, 2 and 3 (each within the scatter of the next, the first and the last beyond it).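

In the Free fatty acid receptor 1 assay, replacing propoxy with hydroxy on the aromatic ring gives no readable change (a 1.7-fold higher number from compound 2 to compound 3 (0.23 log units; within the scatter)), so the propyl on that oxygen is not needed to hold the number within the scatter. Compound 3 does separate from compound 1 in the Free fatty acid receptor 1 assay (a 3.1-fold higher number from compound 1 to compound 3 (0.49 log units; beyond the scatter)), but 4-hydroxy-2-methylphenyl in place of 2-chloro-4-methylphenyl alters more than one feature of that ring, and this step cannot be assigned to any single group. In a physicochemical assay for lipophilicity, read by HPLC, in phosphate buffer, measured as octanol-water partition, at pH 7.4, tested at 100 uM (on this read-out higher numbers stand for higher lipophilicity and lower numbers for lower lipophilicity), compound 2 (3.37) and compound 3 (1.85) lie beyond the scatter of each other. The same propyl-to-hydrogen change that stays within the scatter in the Free fatty acid receptor 1 assay brings a large fall in lipophilicity, so this oxygen tolerates a wide lipophilicity shift without a readable change in that number: the measured distribution coefficient of compound 2, 3.37, and of compound 3, 1.85, a number 1.52 log units lower (beyond the scatter)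

The compounds shown leave open whether a methoxy, a longer chain or a chain ending in an amine or a carboxylic acid on that oxygen would keep the number in the Free fatty acid receptor 1 assay within the same band. They also do not separate the contribution of the chloro group from that of the hydroxy group, since no pair shown differs at only one of these groups.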